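Moving the Pyridine Nitrogen: Cytotoxicity in THP-1 Cells

A few compounds are considered here, and "the series" means these few. Any claim that something is new, unique, unknown or untested is made for them only; others in the source may bear on it.

Compound 2 `O=c1nc(-c2ccccc2)c2ccc(-c3ccncc3)cc2[nH]1` was tested in an ADME assay on THP-1 cells (Homo sapiens) for cytotoxicity, read by MTT assay, with a stated time of 72 h; a higher number here means that more compound is needed for the effect, a lower number that less compound is needed. In this assay compound 2 gives > 50000 nM, which is a limit of the assay rather than a number. Compound 1 `Cc1cc(-c2ccc3[nH]c(=O)nc(-c4ccccc4)c3c2)ccn1` gives > 50000 nM in this assay, also a limit. Both values sit at the limit of > 50000 nM in this assay, at which 2 of the 2 values shown sit. Compound 3 `O=c1nc(-c2ccccc2)c2ccc(-c3cccnc3)cc2[nH]1` carries pyridin-3-yl in place of pyridin-4-yl on an aromatic carbon. Among the compounds with values here, no measured pair shows how such a swap shifts this assay. Because compound 2 reaches > 50000 nM, compound 3 is expected to reach a limit as well. The step of a number no higher from compound 2 to compound 3 (the limit leaves the size open) is expected to be none beyond the scatter. Compound 3 is expected at 50000 nM, with a range from 20000 nM to 100000 nM.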

Compound 3, half-maximal effective concentration: > 50000 nM
Compound 3: no number, only a limit; the forecaster's own chance of this, stated with the estimate: 85%; the middle value lies on the limit itself.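

Within the data shown here, compound 2 and compound 3 both end at a limit in this assay, so no step between them can be read: the limit of > 50000 nM in this assay, at which 3 of the 3 values shown sit. The compounds shown leave open what concentration of any of them would produce the cytotoxic effect.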